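Estimating compound 4 from its nitro-to-fluoro neighbour

The source may hold more compounds than are shown below. What is called first, only, known or untested is meant among the compounds shown, and "the series" means these compounds.

Measured compounds:
Compound 1, `COc1ccc(C(=O)c2ccc(F)cc2)cc1OCC(=O)OC[C@@H]1C=C[C@H](n2cc(C)c(=O)[nH]c2=O)O1`, gives 40300 nM in a functional assay on SMMC-7721 cells (Homo sapiens) for antiproliferative activity, read by MTT assay, with a stated time of 48 h; on this read-out lower numbers stand for stronger inhibition and higher numbers for weaker inhibition.
Compound 2, `COc1ccc(C(=O)c2cccc(Cl)c2)cc1OC(=O)CCC(=O)OC[C@@H]1C=C[C@H](n2cc(C)c(=O)[nH]c2=O)O1`, gives 3210 nM in this assay.
Compound 3, `COc1ccc(C(=O)c2ccc([N+](=O)[O-])cc2)cc1OC(=O)CCC(=O)OC[C@@H]1C=C[C@H](n2cc(C)c(=O)[nH]c2=O)O1`, gives 30500 nM in this assay.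

Among these three numbers compound 3 stands second highest; compound 1 lies closest to it, within the scatter, while compound 2 sits furthest away, beyond the scatter. Compound 4, `COc1ccc(C(=O)c2ccc(F)cc2)cc1OC(=O)CCC(=O)OC[C@@H]1C=C[C@H](n2cc(C)c(=O)[nH]c2=O)O1`, has not been measured. It differs from compound 3 by fluoro in place of nitro on an aromatic carbon. Among the measured compounds shown here, one measured step bears on this change: a 9.5-fold higher number from compound 2 to compound 3 (0.98 log units; beyond the scatter), where a halogen in place of nitro went with the lower number. The two values of compound 1 and compound 4 cannot be compared by any counted step, so only the number of compound 1 is noted. Compound 4 is therefore expected to give a lower number than compound 3, by about a 2.5-fold lower number from compound 3 to compound 4 (0.41 log units; beyond the scatter), though a smaller shift than from chloro is plausible. Compound 4 is estimated at 12000 nM, within 4000 nM to 35000 nM.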

Compound 4, half-maximal inhibitory concentration: 22600 nM
The estimate for compound 4 lay 1.9-fold (0.27 log units) below the measured number; the range from low to high includes it.
By their numbers in this assay, from the lowest: compound 2; then compounds 4, 3 and 1 (each within the scatter of the next).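

In this assay the exchange of nitro for fluoro, para to a large group, gives a 1.3-fold lower number from compound 3 to compound 4 (0.13 log units; within the scatter), a step within the scatter, so at this position the two groups are not told apart even though they differ in heavy atoms and hydrogen-bond acceptors. The 4-fluorophenyl compound also stays clearly apart from the 3-chlorophenyl compound, with a 7.0-fold higher number from compound 2 to compound 4 (0.85 log units; beyond the scatter), which shows that the earlier gap from compound 2 is not peculiar to nitro. Nothing available here accounts for these numbers.

Compound 2 differs from compound 4 in both the halogen and its place on the ring, so the compounds shown do not say which of the two goes with the gap. Nor do they tell whether chloro or an amine, set where fluoro stands, would stay with compound 3 and compound 4 or come closer to compound 2.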